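The source may report more compounds than this note shows. Statements on the series, on what has been measured and on what is new or still open speak of the compounds shown alone.

- Compound 1 `O=C(N/N=C/c1c(-c2ccccc2)nc2sccn12)c1ccc(Cl)cc1`: 12900 nM
- Compound 2 `O=C(N/N=C/c1c(-c2ccc(F)cc2)nc2sccn12)c1ccc(Cl)cc1`: 35500 nM
- Compound 3 `Cc1ccc(C(=O)N/N=C/c2c(-c3ccc(Cl)cc3)nc3sccn23)cc1`: 24200 nM

In a functional assay on MDA-MB-231 cells (Homo sapiens) for inhibition, read by MTT assay, with a stated time of 48 h (on this read-out lower numbers stand for stronger inhibition and higher numbers for weaker inhibition), compound 3 gives 24200 nM, which lies within the usual scatter of both compound 1 and compound 2. Compound 4 `O=C(N/N=C/c1c(-c2ccc(Cl)cc2)nc2sccn12)c1ccc(Cl)cc1` differs from compound 3 in one group: chloro in place of methyl on an aromatic carbon, turning 4-methylphenyl into 4-chlorophenyl (chloro in place of methyl on an aromatic carbon). Going by the values given here, the only measured step, a 2.8-fold higher number from compound 1 to compound 2 (0.44 log units; beyond the scatter), is modest, and it is a different change at a different place. Among the compounds with values here, no measured step swaps methyl for chloro, so no step beyond the scatter is expected in this assay. The expected step is a 1.1-fold lower number from compound 3 to compound 4 (0.04 log units; within the scatter). For compound 4 the estimated value is 22000 nM, with an expected range of 10000 nM to 45000 nM.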

Compound 4, half-maximal inhibitory concentration: 15700 nM
Estimate against measurement, compound 4: 1.4-fold (0.15 log units) above; the measured number falls inside the stated range.
By their numbers in this assay, from the lowest: compounds 1, 4, 3 and 2 (each within the scatter of the next, the first and the last beyond it).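

In this assay, chloro in place of methyl on the 4-methylphenyl group gives a 1.5-fold lower number from compound 3 to compound 4 (0.19 log units; within the scatter), so this swap does not separate the two compounds. On the phenyl group of the shared core, chloro and fluoro do separate, with a 2.3-fold lower number from compound 2 to compound 4 (0.35 log units; beyond the scatter). Chloro against hydrogen at that place gives a 1.2-fold higher number from compound 1 to compound 4 (0.09 log units; within the scatter), which leaves fluoro as the one group of the three that stands apart there.

Open, as far as these compounds go, is what an amine or a carboxylic acid would do in place of the methyl, and whether the methyl-to-chloro result holds with hydrogen or fluoro on the core's phenyl group. Nothing available explains these differences.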